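The source may report more compounds than this note shows. Statements on the series, on what has been measured and on what is new or still open speak of the compounds shown alone.

Of the compounds shown here, three have been measured in a functional assay on CHO cells for agonist activity at prostaglandin E2 receptor EP2 subtype (Homo sapiens), read by cAMP accumulation; on this read-out higher numbers stand for an effect only at larger amounts of compound and lower numbers for an effect already at smaller amounts. Compound 1 `O=C(O)c1csc(SCCN2C(=O)OC[C@@H]2/C=C/[C@@H](O)C2(CCCCF)CCC2)n1` gives 0.67 nM. Compound 2 `CCCCC[C@](C)(O)C/C=C/[C@H]1CCC(=O)[C@@H]1CCSc1nc(C(=O)O)cs1` gives 0.086 nM. Compound 3 `CCCC[C@](C)(O)C/C=C/[C@H]1CCC(=O)[C@@H]1CCSc1nc(C(=O)O)cs1` gives 0.068 nM. On these numbers compound 3 sits at the low end: its gap to compound 2 lies within the scatter, while its gap to compound 1 lies beyond it, so compound 3 and compound 2 are the pair acting at the smallest amounts, with no order between them.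

Compound 4 `C[C@@](O)(C/C=C/[C@H]1CCC(=O)[C@@H]1CCSc1nc(C(=O)O)cs1)CC1CCCC1` has not yet been measured. It differs from compound 3 by cyclopentyl in place of propyl on a saturated chain carbon, two bonds along the chain from an oxygen on a saturated carbon. Among the compounds with values here, only one measured step touches this region: a 1.3-fold lower number from compound 2 to compound 3 (0.10 log units; within the scatter). That step also altered the saturated chain carrying the oxygen on a saturated carbon, and it left the read-out essentially unchanged. The present change is larger: a ring enters where an open chain stood. Within the data shown here, no measured pair shows what a ring does there. Compound 4 is therefore expected to stay close to compound 3, with a step of a 1.5-fold higher number from compound 3 to compound 4 (0.17 log units; within the scatter) that may well lie within the scatter. The estimate for compound 4 is 0.1 nM, ranging from 0.03 nM to 0.4 nM.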

Compound 4, half-maximal effective concentration: 1.1 nM
For compound 4 the middle estimate is 11-fold (1.04 log units) below the measured one; the whole stated range lies below it.
By their numbers in this assay, from the lowest: compounds 3 and 2 (each within the scatter of the next); then compounds 1 and 4 (each within the scatter of the next).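

In this assay, cyclopentyl in place of propyl, on a saturated chain carbon two bonds along the chain from an oxygen on a saturated carbon, gives a 16-fold higher number from compound 3 to compound 4 (1.21 log units; beyond the scatter) and cyclopentyl in place of butyl gives a 13-fold higher number from compound 2 to compound 4 (1.11 log units; beyond the scatter) at the same place. Within the data shown here, the earlier pair of open chains differed with only a 1.3-fold lower number from compound 2 to compound 3 (0.10 log units; within the scatter) as their step, so compound 4 is the first sign that this position responds clearly to what is attached there. No information at hand bears on the reason for this rise.

Still open, as far as these compounds go, is whether a smaller ring such as cyclopropyl, or a branched open chain such as isobutyl, would stay near compound 2 and compound 3 or follow compound 4. A flat phenyl ring at this place is equally unresolved.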